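Anticonvulsant activity of aryl piperazine succinimides

This account rests on a few compounds, and the source may have more. Where it says the series, first, only, none or still open, it means among the compounds named here.

Measured compounds:
compound 1, `CCC(C(=O)N1CCN(c2cccc(F)c2)CC1)N1C(=O)CCC1=O`: 75%
compound 2, `CCC(C(=O)N1CCN(c2ccc(F)cc2)CC1)N1C(=O)CCC1=O`: 25%
compound 3, `CCC(C(=O)N1CCN(c2ccccc2F)CC1)N1C(=O)CCC1=O`: 50%

In a functional assay on the whole organism (strain Swiss) with Mus musculus as the target, in the maximal electroshock model, with a stated time of 1 h, at a dose of 300 mg/kg by the intraperitoneal route (on this read-out lower numbers stand for a weaker effect and higher numbers for a stronger effect at the one dose given), compound 3 stands second highest of the three numbers; its nearest neighbour is compound 1, which lies above it by a number 25 percentage points lower from compound 1 to compound 3 (beyond the scatter), while compound 2 lies below it by a number 25 percentage points higher from compound 2 to compound 3 (beyond the scatter). Compound 4, `CCC(C(=O)N1CCN(c2cccc(C)c2)CC1)N1C(=O)CCC1=O`, is not yet measured. It differs from compound 3 in one place: 3-methylphenyl in place of 2-fluorophenyl on an amine nitrogen in a ring.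

Among the measured compounds shown here, no measured step changes fluorine for methyl, so that part of the change has no precedent here. For the measured compounds named here, the steps that bear on it are those that move the fluorine about the ring: a number 25 percentage points lower from compound 1 to compound 3 (beyond the scatter) and a number 50 percentage points lower from compound 1 to compound 2 (beyond the scatter), both beyond the scatter, with the 3-substituted compound 1 giving the highest number. Since compound 4 carries its group at the 3-position, a modest rise in this assay is expected, though with wide uncertainty because the entering group is new, expected as a number 12 percentage points higher from compound 3 to compound 4 (beyond the scatter). Compound 4 is therefore estimated at 62%, within 25% to 100%.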

Compound 4, a percentage reported as activity, at one dose (the size of the read-out at that dose, not a potency): 75%
For compound 4 the middle estimate is 13 percentage points below the measured one; measured number inside the range.
By their numbers in this assay, from the lowest: compound 2; then compound 3; then compounds 1 and 4 (each within the scatter of the next).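

In this assay, the step with methyl in place of fluoro, no change at the digits printed from compound 1 to compound 4 (within the scatter), shows that this position on the phenyl ring tolerates a carbon group as well as a fluorine, with the 3-methylphenyl and 3-fluorophenyl compounds reading alike. Compound 4 also stands clear of both other fluorophenyl compounds, with a number 25 percentage points higher from compound 3 to compound 4 (beyond the scatter) and a number 50 percentage points higher from compound 2 to compound 4 (beyond the scatter), so among the four compounds both groups named with a 3 stand above the 2-fluorophenyl and 4-fluorophenyl compounds. No measurement shown here gives a cause for this match.

Going by these compounds, it remains open whether a methyl group elsewhere on the phenyl ring would repeat the differences seen among the three fluorophenyl compounds. Also open, on these data alone, is whether a chlorine, a methoxy or an ethyl group in place of the methyl would keep the number of compound 4.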